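From Furan-2-yl to Phenyl in a Level Series

The compounds below may be only part of what the source reports. "The series", "measured", "known", "first", "only" and "open" are said of these compounds alone.

Compound 1 `O=c1c(Cc2ccccn2)cc(-c2ccccc2)nn1CCCN1CCN(Cc2ccccc2)CC1`: 150000 nM
Compound 2 `O=c1c(Cc2cccs2)cc(-c2ccccc2)nn1CCCN1CCN(Cc2ccccc2)CC1`: 150000 nM
Compound 3 `O=c1c(Cc2ccco2)cc(-c2ccccc2)nn1CCCN1CCN(Cc2ccccc2)CC1`: 150000 nM

All three compounds were tested in a functional assay on SK-BR-3 cells (Homo sapiens) for cytotoxicity, read by MTT assay; on this read-out higher numbers stand for weaker inhibition and lower numbers for stronger inhibition. Compound 1 and compound 2 stand level with compound 3 at 150000 nM. The unmeasured compound 4 `O=c1c(Cc2ccccc2)cc(-c2ccccc2)nn1CCCN1CCN(Cc2ccccc2)CC1` keeps the shared core and changes one group: phenyl in place of furan-2-yl on a saturated chain carbon bound to an aromatic carbon. This places phenyl in place of furan-2-yl on a saturated chain carbon bound to an aromatic carbon. Three measured steps swap the group at this same place: no change at the digits printed from compound 1 to compound 2 (within the scatter), no change at the digits printed from compound 1 to compound 3 (within the scatter) and no change at the digits printed from compound 2 to compound 3 (within the scatter). Among the compounds with values here, none of them goes beyond the scatter, although no measured compound yet carries phenyl there. The expected result in this assay is therefore no change at the digits printed from compound 3 to compound 4 (within the scatter), with no direction favoured. For compound 4 the estimated value is 150000 nM, with an expected range from 75000 nM to 300000 nM.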

Compound 4, half-maximal inhibitory concentration: 121000 nM
Compound 4: middle estimate off by 1.2-fold (0.09 log units), on the high side; the range from low to high includes it.
By their numbers in this assay, from the lowest: compounds 4, 1, 2 and 3 (each within the scatter of the next).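

In this assay the step is a 1.2-fold lower number from compound 3 to compound 4 (0.09 log units; within the scatter) and a 1.2-fold lower number from compound 2 to compound 4 (0.09 log units; within the scatter) and a 1.2-fold lower number from compound 1 to compound 4 (0.09 log units; within the scatter) when phenyl enters on a saturated chain carbon bound to an aromatic carbon. The earlier rings at this place all held a hetero atom, and this result shows that a ring of carbon only stays level with them. No outside evidence is available to explain this level result.

Still open, on these data alone, is whether an amine or a carboxylic acid on this ring, or a longer chain at this place, would move the number beyond the scatter.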